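Spiro piperidine series: clearance outlook for a pyrrolyl analogue

The source may hold more compounds than are shown below. What is called first, only, known or untested is meant among the compounds shown, and "the series" means these compounds.

Working notes on a set of spiro-fused piperidines sharing the core of compound 1 `c1cc2c(s1)CCOC21CCNCC1`. In an ADME assay on microsomes from liver (Mus musculus) for metabolic stability, read by LC-MS, using NADPH, with a stated time of 30 min, tested at 0.5 uM (a higher number here means faster removal of the compound, a lower number slower removal), compound 1 gives "not determined" (no result reported). Compound 2 `Cc1ccc(CN2CCC3(CC2)OCCc2sccc23)cc1` carries a benzyl-type substituent on the piperidine nitrogen; in this assay compound 2 reaches only a limit, > 30 mL/min/g, not a number. Compound 3 `Cc1ccccc1CN1CCC2(CC1)OCCc1sccc12` stands without any number in this assay, "not determined" (no result reported); the only quantitative point in the set is the limit of > 30 mL/min/g in this assay, at which 1 of the 3 values shown sits. Compound 4 `Cc1ccc(CN2CCC3(CC2)OCCc2sccc23)[nH]1` differs from compound 3 by 5-methyl-1H-pyrrol-2-yl in place of 2-methylphenyl on a saturated chain carbon bound to an amine nitrogen in a ring. Within the data shown here, no measured step exists between compound 3 and compound 4, so the size of the step in this assay cannot be taken from the data. Compound 4 is expected to show rapid removal, estimated at 30 mL/min/g with a range from 12 mL/min/g to 60 mL/min/g.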

Compound 4, intrinsic clearance in a liver preparation (reported as CLH), per the amount of preparation that the assay uses: 28.7 mL/min/g
Compound 4: middle estimate off by 1.0-fold (0.02 log units), on the high side; low and high end bracket the measured number.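

Among these compounds, compound 4 gives the first single number at this position in this assay, 28.7 mL/min/g. Replacing 4-methylphenyl with 5-methyl-1H-pyrrol-2-yl on a saturated chain carbon bound to an amine nitrogen in a ring gives an at least 1.0-fold lower number from compound 2 to compound 4 (0.01 log units; that floor lies within the scatter), a floor that shows no drop beyond the scatter. Compound 2 stays a limit, not a number: the limit of > 30 mL/min/g in this assay, at which 1 of the 4 values shown sits.

As far as these compounds go, the step from compound 3 cannot be read, and the full size of the step from compound 2 remains unknown. From the compounds shown here alone, how a pyridin-2-yl group or a carboxylic acid would behave in this place remains open.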